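A Single Halogen Swap on the Weakest Compound

The source may hold more compounds than are shown below. What is called first, only, known or untested is meant among the compounds shown, and "the series" means these compounds.

In a functional assay on DU-145 cells (Homo sapiens) for cytotoxicity, read by trypan blue exclusion, with a stated time of 96 h (a lower number here means a stronger inhibitor, a higher number a weaker inhibitor), compound 1 `COc1cc(OC)c(/C=C/S(=O)(=O)Nc2ccc(OC)c(N)c2)c(OC)c1` gives 5 nM. Compound 2 `COC(=O)C(C)(C)Nc1cc(NS(=O)(=O)/C=C/c2c(OC)cc(OC)cc2OC)ccc1OC` gives 200 nM, and compound 3 `COC(=O)C(Nc1cc(NS(=O)(=O)/C=C/c2c(OC)cc(OC)cc2OC)ccc1OC)c1ccc(F)cc1` gives 2500 nM, the highest number of the three and so the weakest inhibitor among them. The measured steps are a 40-fold higher number from compound 1 to compound 2 (1.60 log units; beyond the scatter), a 500-fold higher number from compound 1 to compound 3 (2.70 log units; beyond the scatter) and a 13-fold higher number from compound 2 to compound 3 (1.10 log units; beyond the scatter). All three are large and beyond the scatter, but each changes the whole group on the nitrogen.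

Compound 4 `COC(=O)C(Nc1cc(NS(=O)(=O)/C=C/c2c(OC)cc(OC)cc2OC)ccc1OC)c1ccc(Cl)cc1` differs from compound 3 in one small way: chloro in place of fluoro on an aromatic carbon. This places chloro where fluoro stood on an aromatic carbon, para to a large group, while the rest of the molecule stays the same. Among the measured compounds shown here, no measured pair changes this halogen, so the large steps above bear on it only indirectly and give no direction. The expected step is therefore no change at the digits printed from compound 3 to compound 4 (within the scatter), with no shift beyond the scatter anticipated. In this assay the estimate for compound 4 is 2500 nM, with an expected range from 800 nM to 8000 nM.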

Compound 4, half-maximal inhibitory concentration: 5000 nM
For compound 4 the middle estimate is 2.0-fold (0.30 log units) below the measured one; the range from low to high includes it.
By their numbers in this assay, from the lowest: compound 1; then compound 2; then compounds 3 and 4 (each within the scatter of the next).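

In this assay, chloro in place of fluoro is the only change among these compounds that touches a single atom, and it gives a 2.0-fold higher number from compound 3 to compound 4 (0.30 log units; within the scatter), so at this position the swap makes no difference that can be told from the scatter. The large gaps stay with the whole group on the nitrogen, since the (4-chlorophenyl)(methoxycarbonyl)methyl compound still shows a 25-fold higher number from compound 2 to compound 4 (1.40 log units; beyond the scatter) and a 1000-fold higher number from compound 1 to compound 4 (3.00 log units; beyond the scatter). Exchanging one halogen for the other therefore does nothing to close the distance to compound 1, which carries only hydrogen in that place.

Nothing measured here gives a reason for any of these steps. Still open, going by these compounds, is how this position responds to something other than these two halogens, such as a plain hydrogen, a methoxy group or an amine, and whether a carboxylic acid in place of the methoxycarbonyl group would change the picture.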